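Phenoxy in place of tert-butyl on compound 2

The compounds below may be only part of what the source reports. "The series", "measured", "known", "first", "only" and "open" are said of these compounds alone.

Compound 1 `CCCCOC(=O)CNC(=O)[C@H](CSc1ccc([N+](=O)[O-])cc1[N+](=O)[O-])NC(=O)CC[C@H](NC(=O)OC(C)(C)C)C(=O)OCCCC` gives 70.4 uM
Compound 2 `CCCCOC(=O)CNC(=O)[C@H](CSc1ccc([N+](=O)[O-])cc1[N+](=O)[O-])NC(=O)CC[C@H](NC(=O)CC(C)(C)C)C(=O)OCCCC` gives 250 uM

Within the data shown here, in a toxicity assay on KB cells (Homo sapiens) for cytotoxicity, read by fluorescence, with a stated time of 3 days (on this read-out higher numbers stand for an effect only at larger amounts of compound and lower numbers for an effect already at smaller amounts), compound 2 stands at the higher of the two numbers (250 uM), with compound 1 as its only neighbour. Compound 3 `CCCCOC(=O)CNC(=O)[C@H](CSc1ccc([N+](=O)[O-])cc1[N+](=O)[O-])NC(=O)CC[C@H](NC(=O)COc1ccccc1)C(=O)OCCCC` keeps the shared core and carries phenoxy in place of tert-butyl on a saturated chain carbon bound to a carbonyl carbon. Among the measured compounds shown here, only one measured step bears on this change: a 3.6-fold higher number from compound 1 to compound 2 (0.55 log units; beyond the scatter), with neopentyl in place of tert-butoxy on a carbonyl carbon. Neopentyl on that carbonyl carbon is the group that is replaced in going to compound 3 as well, although no measured compound carries a ring there, so the guidance is thin. Compound 2 sits at the high end of the two numbers (250 uM), so a modest step towards a lower number is expected in this assay, of roughly the size seen between the two measured compounds or smaller. The estimated step is a 2.1-fold lower number from compound 2 to compound 3 (0.32 log units; beyond the scatter). For compound 3 the expected value is 120 uM, with an estimated range from 45 uM to 300 uM.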

Compound 3, concentration for half-maximal effect: > 300 uM
Compound 3: a limit, no number (the forecaster's own chance of this, stated with the estimate: 15%); at least 2.5-fold (0.39 log units) between middle value and limit.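

In this assay, going by these compounds, compound 3 gives > 300 uM, a limit of the assay and not a number, so the sizes of its steps remain open on one side: the limit of > 300 uM in this assay, at which 1 of the 3 values shown sits. Phenoxy in place of tert-butyl on a saturated chain carbon bound to a carbonyl carbon puts a six-membered aromatic ring at this position for the first time among these compounds, and the reading is an at least 1.2-fold higher number from compound 2 to compound 3 (0.07 log units; that floor lies within the scatter), which gives no sign of a move towards a lower number but, with its floor inside the scatter, does not establish a rise either. The comparison with the tert-butoxy compound is firmer, with an at least 4.2-fold higher number from compound 1 to compound 3 (0.62 log units; beyond the scatter), so compound 1 now stands lowest of the three, with both of its steps beyond the scatter.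

On these data alone, what a benzyl group, a longer alkyl chain or an amine would do in place of phenoxymethyl remains open, and so does whether the ring or the oxygen of phenoxy matters more here. As far as these compounds go, it is also open whether a methoxy group on that carbonyl carbon would read close to compound 1.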